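The compounds below may be only part of what the source reports. "The series", "measured", "known", "first", "only" and "open" are said of these compounds alone.

Going by the values given here, compound 1 `O=C1NC(O)(CCn2cnc3ccnc(Cl)c32)C(OCc2ccccc2)=C1OCc1ccccc1` is one of two compounds measured in a functional assay on HeLa cells (Homo sapiens) for antiproliferative activity, read by MTT assay, with a stated time of 72 h (on this read-out lower numbers stand for stronger inhibition and higher numbers for weaker inhibition), where compound 1 gives 21000 nM. The other, compound 2 `O=C1O/C(=C\Cn2cnc3ccn(C/C=C4\OC(=O)C(OCc5ccccc5)=C4OCc4ccccc4)c3c2=O)C(OCc2ccccc2)=C1OCc1ccccc1`, gives 5600 nM in this assay, so compound 1 stands with the higher of the two numbers and compound 2 with the lower, a gap beyond the scatter of the method. Compound 3 `Nc1nc(F)c(Cl)c2c1ncn2CCC1(O)NC(=O)C(OCc2ccccc2)=C1OCc1ccccc1` has not been measured. It differs from compound 1 by a group of 12 heavy atoms (6 carbon, 4 nitrogen, 1 fluorine, 1 chlorine; one five-membered aromatic ring with 2 hetero atoms, one six-membered aromatic ring with 1 hetero atom) in place of a group of 10 heavy atoms (6 carbon, 3 nitrogen, 1 chlorine; one five-membered aromatic ring with 2 hetero atoms, one six-membered aromatic ring with 1 hetero atom), on a saturated chain carbon, two bonds along the chain from a saturated ring carbon; the shared core of compound 1 is otherwise kept. Among the compounds with values here, no measured pair shows what such a change does in this assay, so there is no step to lean on. The step from compound 1 to compound 3 is expected to be small, a 1.3-fold lower number from compound 1 to compound 3 (0.12 log units; within the scatter), with no clear direction beyond the scatter. Compound 3 is therefore estimated at 16000 nM in this assay, within a range from 5000 nM to 50000 nM.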

Compound 3, half-maximal inhibitory concentration: 39000 nM
Beside the measured number, compound 3's estimate is 2.4-fold (0.39 log units) below it, and the stated range covers the measured number.
By their numbers in this assay, from the lowest: compound 2; then compounds 1 and 3 (each within the scatter of the next).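

In this assay, placing the group of 12 heavy atoms in place of the group of 10 heavy atoms, on a saturated chain carbon, two bonds along the chain from a saturated ring carbon, gives a 1.9-fold higher number from compound 1 to compound 3 (0.27 log units; within the scatter), so this read-out does not separate the two groups. Going by these compounds alone, this is the first measured step at this position, and it shows that the exchange, which also brings 1 hydrogen-bond donor against 0 and adds a fluorine, leaves compound 3 within the scatter of compound 1. No measured property of these groups accompanies the step, so nothing supports an explanation of this result.

The compounds shown leave open what an amine alone or a fluorine alone would do on the group of 10 heavy atoms, since both arrive together in this step. They also leave open whether a longer chain at this place would move the number beyond the scatter.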